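A few compounds are considered here, and "the series" means these few. Any claim that something is new, unique, unknown or untested is made for them only; others in the source may bear on it.

Compound 1 `COc1ccccc1OCCNc1cnn(Cc2ccc(OC)c(OCC3CC3)c2)c(=O)c1Cl`: > 100000 nM (a limit)
Compound 2 `COc1ccc(Cn2nc(NCCOc3ccccc3OC)ccc2=O)cc1Br`: > 100000 nM (a limit)
Compound 3 `COc1ccccc1OCCNc1cnn(Cc2ccc(OC(F)F)c(OCC3CC3)c2)c(=O)c1Cl`: 67600 nM

Compound 1 has no number in a functional assay on K562 cells (Homo sapiens) for antiproliferative activity, read by MTT assay, with a stated time of 48 h (on this read-out higher numbers stand for weaker inhibition of growth and lower numbers for stronger inhibition of growth), and stands at the limit of > 100000 nM in this assay, at which 2 of the 3 values shown sit. Compound 4 `COc1ccccc1OCCNc1cnn(Cc2ccc(OC)c(OC3CCCC3)c2)c(=O)c1Cl` carries cyclopentyl in place of cyclopropylmethyl on an oxygen on an aromatic ring. For the measured compounds named here, the only measured step bearing on this is an at least 1.4-fold lower number from compound 1 to compound 3 (0.17 log units; that floor lies within the scatter), a swap of difluoromethyl for methyl on a different oxygen, so it offers only indirect guidance. Going by the values given here, no measured step changes the cyclopropylmethyl group itself. Given that compound 1 shows no measurable number and that step stays within the scatter, a number no higher from compound 1 to compound 4 (the limit leaves the size open) is expected to be no step beyond the scatter. Compound 4 is estimated at 100000 nM, with an expected range of 50000 nM to 200000 nM.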

Compound 4, concentration for 50% growth inhibition: > 100000 nM
Compound 4: no number, only a limit; the forecaster's own chance of this, stated with the estimate: 65%; the middle value lies on the limit itself.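

In this assay, compound 1 and compound 4 each give only a limit, so no step between them can be read: the limit of > 100000 nM in this assay, at which 3 of the 4 values shown sit.

Left open is whether cyclopentyl and cyclopropylmethyl on this oxygen differ at all in this assay.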